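Methoxy to Ethoxy on the Aryl Triazole Arm

The source may report more compounds than this note shows. Statements on the series, on what has been measured and on what is new or still open speak of the compounds shown alone.

Compound 1 `N#CC1=C(N)Oc2c(N)cc3nc4ccccc4nc3c2C12C(=O)N(Cc1cnnn1-c1cccc(Br)c1)c1ccccc12` and compound 2 `COc1ccc(-n2nncc2CN2C(=O)C3(C(C#N)=C(N)Oc4c(N)cc5nc6ccccc6nc5c43)c3ccccc32)cc1` share one core and differ only in the aryl group carried on the triazole nitrogen. In a functional assay on A549 cells (Homo sapiens) for antiproliferative activity, read by MTT assay, with a stated time of 48 h (a higher number here means a weaker inhibitor, a lower number a stronger inhibitor), compound 1 gives 18900 nM. In this assay the value of compound 2, > 50000 nM, is a limit of the assay and not a number. Hence there is an at least 2.6-fold higher number from compound 1 to compound 2 (0.42 log units; beyond the scatter). Compound 2 thus stands at the weak end of the two values shown, as the limit of > 50000 nM in this assay, at which 1 of the 2 values shown sits, marks. Compound 3 `CCOc1ccc(-n2nncc2CN2C(=O)C3(C(C#N)=C(N)Oc4c(N)cc5nc6ccccc6nc5c43)c3ccccc32)cc1` differs from compound 2 by methyl in place of hydrogen on a saturated chain carbon bound to an oxygen on an aromatic ring. Going by the values given here, no measured step concerns this change directly; the only measured step, an at least 2.6-fold higher number from compound 1 to compound 2 (0.42 log units; beyond the scatter), alters the aryl group itself and points to the weak side, and compound 2 already sits at the limit. A shift within the scatter is therefore expected, a step that the limit leaves unreadable from compound 2 to compound 3, with no direction established beyond that scatter. Compound 3 is accordingly estimated at 60000 nM, expected to lie between 20000 nM and 180000 nM, and it is most likely to be reported again only as a limit.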

Compound 3, half-maximal inhibitory concentration: > 50000 nM
Compound 3: no number, only a limit; the forecaster's own chance of this, stated with the estimate: 75%; the middle value does not contradict the limit.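

In this assay compound 3 gives > 50000 nM, which is a limit of the assay and not a number. The step from compound 2 to compound 3 cannot be read, as both values are limits, so the change from methoxy to ethoxy has no readable size, but exchanging 3-bromophenyl for 4-ethoxyphenyl on the aromatic nitrogen gives an at least 2.6-fold higher number from compound 1 to compound 3 (0.42 log units; beyond the scatter), which shows that a second 4-substituted aryl group, not only 4-methoxyphenyl, falls on the weak side of 3-bromophenyl. Adding the methyl to the methoxy group thus leaves the compound at the limit, which now holds most of the series: the limit of > 50000 nM in this assay, at which 2 of the 3 values shown sit.

What the compounds shown leave open is whether this loss follows from removing the bromine, from moving to the 4-substituted aryl group, or from the oxygen-linked chain itself. A 4-bromophenyl or a 3-methoxyphenyl group on the triazole nitrogen would separate these readings, and only a value that is a number could rank such compounds against compound 1.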